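The compounds below may be only part of what the source reports. "The series", "measured", "known", "first", "only" and "open" are said of these compounds alone.

In a physicochemical assay for metabolic stability, in phosphate buffer, at pH 7.4 (a lower number here means that the compound disappears faster, a higher number that the compound lasts longer), compound 2 `Cc1nc(C)c(C(=O)N[C@@H](C(=O)Oc2ccc(-c3cc(=O)c4c(O)c(O)c(O)cc4o3)cc2)C(C)C)nc1C` gives > 72 h, a limit of the assay and not a number. Compound 3 `Cc1nc(C)c(C(=O)N[C@H](CC(C)C)C(=O)Oc2ccc(-c3cc(=O)c4c(O)c(O)c(O)cc4o3)cc2)nc1C` gives 69.2 h. Within the data shown here, the only measured step, an at least 1.0-fold lower number from compound 2 to compound 3 (0.01 log units; that floor lies within the scatter), stays within the scatter and does not touch the group that changes next. Compound 4 `Cc1nc(C)c(COC(=O)N[C@@H](C(=O)Oc2ccc(-c3cc(=O)c4c(O)c(O)c(O)cc4o3)cc2)C(C)C)nc1C` differs from compound 2 as follows: (3,5,6-trimethylpyrazin-2-yl)methoxy in place of 3,5,6-trimethylpyrazin-2-yl on a carbonyl carbon. Among the measured compounds shown here, no measured step covers this change. Compound 1 `Cc1nc(C)c(COC(=O)COc2ccc(-c3cc(=O)c4c(O)c(O)c(O)cc4o3)cc2)nc1C`, which also carries (3,5,6-trimethylpyrazin-2-yl)methoxy on a carbonyl carbon, gives 21.4 h, so a lower number is expected in this assay. The expected change is an at least 1.5-fold lower number from compound 2 to compound 4 (0.17 log units; that floor lies within the scatter). For compound 4 the estimate is 48 h, with an expected range of 22 h to 100 h.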

Compound 4, half-life: 45.6 h
The estimate for compound 4 lay 1.1-fold (0.02 log units) above the measured number, within the range that was stated.
By their numbers in this assay, from the lowest: compound 1; then compounds 4 and 3 (each within the scatter of the next). At a limit, above all of these: compound 2.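

In this assay, among these compounds, (3,5,6-trimethylpyrazin-2-yl)methoxy in place of 3,5,6-trimethylpyrazin-2-yl, on a carbonyl carbon bound to an amide-type nitrogen, gives an at least 1.5-fold lower number from compound 2 to compound 4 (0.19 log units; that floor lies within the scatter) as the first reading at this position. Compound 4 gives 45.6 h as a number, so this group can now be read at this position. On these data alone, the full size of the step stays unknown, because the value for compound 2 is a limit and not a number: the limit of > 72 h in this assay, at which 1 of the 4 values shown sits.

Open, as far as these compounds go, is how an amine or a longer chain on this carbonyl carbon would read, and whether the step holds with isobutyl in place of isopropyl.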